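A few compounds are considered here, and "the series" means these few. Any claim that something is new, unique, unknown or untested is made for them only; others in the source may bear on it.

In a functional assay on the whole organism (heart, strain Wistar) for inhibition, with Rattus norvegicus as the target, with a stated time of 15 min, at a dose of 1 mg/kg by the intravenous route (on this read-out lower numbers stand for an effect already at smaller amounts and higher numbers for an effect only at larger amounts of compound), compound 1 `COc1ccccc1OCCNC[C@H](O)COc1c(OC)ccc2[nH]ccc12` gives 0.3 mg/kg and compound 2 `COc1ccccc1OCCNCC(O)COc1cccc2[nH]ccc12` gives 0.34 mg/kg, two values within the usual scatter of each other. Compound 3 `COc1ccccc1OCCNCC(O)COc1c(OC)ccc2[nH]ccc12` differs from compound 2 by one change, (methoxy in place of hydrogen on an aromatic carbon), with methoxy in place of hydrogen on an aromatic carbon. Compound 1 also carries this methoxy and gives 0.3 mg/kg, so no step beyond the scatter is expected in this assay. The estimated move is a 1.0-fold lower number from compound 2 to compound 3 (0.01 log units; within the scatter). Compound 3 is expected at 0.33 mg/kg, within a range of 0.15 mg/kg to 0.75 mg/kg.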

Compound 3, dose for half-maximal effect: 0.38 mg/kg
Beside the measured number, compound 3's estimate is 1.2-fold (0.06 log units) below it, and the stated range covers the measured number.
By their numbers in this assay, from the lowest: compounds 1, 2 and 3 (each within the scatter of the next).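

In this assay, methoxy in place of hydrogen on an aromatic carbon gives a 1.1-fold higher number from compound 2 to compound 3 (0.05 log units; within the scatter) and so this direct comparison shows no step beyond the scatter at this place. The comparison of the defined and undefined drawings gives a 1.3-fold higher number from compound 1 to compound 3 (0.10 log units; within the scatter) and this also lies within the scatter. That pair differs in one respect only: the fact that one of compounds 1 and 3 is drawn with a defined configuration and the other without, at the place where they differ.

On these data alone, whether a hydroxyl, an ethoxy or an amine at this place would give a step beyond the scatter stays open. So does the value of the form drawn with the opposite configuration.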